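The source may hold more compounds than are shown below. What is called first, only, known or untested is meant among the compounds shown, and "the series" means these compounds.

Compound 1, `COc1ccccc1NC(=O)c1ccc2cccc(O)c2n1`: in an ADME assay on THP-1 cells (Homo sapiens) for cytotoxicity, read by WST assay, with a stated time of 24 h (a higher number here means a weaker inhibitor, a lower number a stronger inhibitor), compound 1 gives > 30000 nM.
Compound 2, `O=C(Nc1ccc(F)cc1)c1ccc2cccc(O)c2n1`: in this assay compound 2 gives > 30000 nM.

Compound 2 is the starting point here. Its value is not a number but a limit: the measurement reached the top of the tested range without finding a half-maximal effect. The same holds across the small set, as both measured compounds sit at the limit of > 30000 nM in this assay, at which 2 of the 2 values shown sit. Compound 3, `O=C(Nc1ccccc1Cl)c1ccc2cccc(O)c2n1`, differs from compound 2 in one place: 2-chlorophenyl in place of 4-fluorophenyl on an amide-type nitrogen. For the measured compounds named here, no step between two measured compounds is available, so the size of this change cannot be read from a precedent. The expectation is that the step that the limit leaves unreadable from compound 2 to compound 3 shows no change beyond the usual scatter. Compound 3 is therefore estimated at 40000 nM, with a likely range from 20000 nM to 80000 nM, and the assay will most probably again report only a limit.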

Compound 3, half-maximal inhibitory concentration: > 30000 nM
Compound 3 was reported as a limit (the forecaster's own chance of this, stated with the estimate: 80%); the middle value is on the limit's open side.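

The results for compound 1, compound 2 and compound 3 are all limits, so no step among these compounds can be read: the limit of > 30000 nM in this assay, at which 3 of the 3 values shown sit. The compounds shown leave open how strongly each one acts in this assay, and whether 2-chlorophenyl and 4-fluorophenyl differ there at all.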